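Halogen for Trifluoromethyl on the Shared Core

The compounds below may be only part of what the source reports. "The series", "measured", "known", "first", "only" and "open" are said of these compounds alone.

Compound 1 `FC(F)(F)c1ccc(C2=NN(C(=S)Nc3ccccc3)C(c3ccc4c(c3)OCCO4)C2)cc1` holds the lowest of the two numbers shown, and in a functional assay on HCT-116 cells (Homo sapiens) for antiproliferative activity, read by MTT assay, with a stated time of 48 h (a higher number here means a weaker inhibitor of growth, a lower number a stronger inhibitor of growth), compound 1 gives 112000 nM. Among the measured compounds shown here, its only neighbour, compound 2 `S=C(Nc1ccccc1)N1N=C(c2ccccc2Br)CC1c1ccc2c(c1)OCCO2`, gives 195000 nM in this assay, and the step of a 1.7-fold higher number from compound 1 to compound 2 (0.24 log units; within the scatter) shows that exchanging the group on that carbon left the read-out essentially unchanged. Compound 3 `S=C(Nc1ccccc1)N1N=C(c2cccc(Cl)c2)CC1c1ccc2c(c1)OCCO2` has not yet been measured. It differs from compound 1 in one place: 3-chlorophenyl in place of 4-(trifluoromethyl)phenyl on a carbon with a double bond to nitrogen. For the measured compounds named here, the only measured step that bears on this change is a 1.7-fold higher number from compound 1 to compound 2 (0.24 log units; within the scatter), a replacement of the same group on the same carbon that stayed within the scatter. No step beyond the scatter is therefore expected for compound 3 in this assay. Compound 3 is thus expected to give about 130000 nM, within 55000 nM to 310000 nM, corresponding to an expected step of a 1.2-fold higher number from compound 1 to compound 3 (0.06 log units; within the scatter).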

Compound 3, concentration for 50% growth inhibition: 138000 nM
For compound 3 the middle estimate is 1.1-fold (0.03 log units) below the measured one, and the stated range covers the measured number.
By their numbers in this assay, from the lowest: compounds 1, 3 and 2 (each within the scatter of the next).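

In this assay the step of a 1.2-fold higher number from compound 1 to compound 3 (0.09 log units; within the scatter) and the step of a 1.4-fold lower number from compound 2 to compound 3 (0.15 log units; within the scatter) both stay within the scatter, so three different substituted phenyl groups on the carbon with a double bond to nitrogen now cannot be told apart by this read-out. The earlier pair offered a single exchange, whereas 3-chlorophenyl adds a second halogen and a third place of substitution on the phenyl ring, and it still does not separate from 4-(trifluoromethyl)phenyl or 2-bromophenyl. Nothing available here gives a cause for this result.

As far as these compounds go, all three compounds carry a halogen or trifluoromethyl on that phenyl ring, so it remains open whether an amine or a carboxylic acid there would give a step beyond the scatter. From the compounds shown here alone, it also remains open whether replacing the 2,3-dihydro-1,4-benzodioxin-6-yl group would do so.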